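The source may report more compounds than this note shows. Statements on the series, on what has been measured and on what is new or still open speak of the compounds shown alone.

Three compounds have already been tested in a functional assay on PC-3 cells (Homo sapiens) for antiproliferative activity, read by MTT assay, with a stated time of 24 h; on this read-out higher numbers stand for weaker inhibition and lower numbers for stronger inhibition:

Compound 1, `CCN(CC)CCNC(=O)c1ccc(C(CC)(CC)c2ccc(OCS(=O)(=O)c3ccccc3)c(C)c2)n1CC`, gives 7130 nM.
Compound 2, `CCN(CC)CCNC(=O)c1ccc(C(CC)(CC)c2ccc(OCS(C)(=O)=O)c(C)c2)n1CC`, gives 46700 nM.
Compound 3, `CCN(CC)CCNC(=O)c1cc(C(CC)(CC)c2ccc(OCSC)c(C)c2)cn1CC`, gives 9540 nM.

Compound 2 and compound 1 differ in one place only, (phenyl in place of methyl on a sulfonyl sulfur), and that step is a 6.5-fold lower number from compound 2 to compound 1 (0.82 log units; beyond the scatter). Compound 3 carries the same side chain as compound 2 but a different core; the difference between the two cores is not broken down here. Compound 3 and compound 1 give numbers that lie within the usual scatter of each other.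

Compound 4, `CCN(CC)CCNC(=O)c1cc(C(CC)(CC)c2ccc(OCSc3ccccc3)c(C)c2)cn1CC`, has not yet been measured. It differs from compound 3 by phenyl in place of methyl on a sulfur. Here the change sits on a sulfur rather than on a sulfonyl sulfur, so it is the same kind of change as that from compound 2 to compound 1, not the same one. For compound 4 the step is expected to be a 3.8-fold lower number from compound 3 to compound 4 (0.58 log units; beyond the scatter), taken a little smaller than the earlier one because the move from compound 2 to compound 1 gave a 6.5-fold lower number from compound 2 to compound 1 (0.82 log units; beyond the scatter) while the place and the core here differ. Compound 4 is therefore estimated at 2500 nM, expected to fall between 1000 nM and 7000 nM.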

Compound 4, half-maximal inhibitory concentration: 2620 nM
Compound 4: the middle estimate sits 1.0-fold (0.02 log units) below what was measured; the measured number falls inside the stated range.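

In this assay, phenyl in place of methyl on a sulfur gives a 3.6-fold lower number from compound 3 to compound 4 (0.56 log units; beyond the scatter), so the number drops on this core as it did on the core of compound 1, where the same kind of swap sits on a sulfonyl sulfur. The two steps run in the same direction, and their sizes cannot be told apart in this assay: the same change on two cores in this assay, a 6.5-fold lower number (0.82 log units; beyond the scatter) from compound 2 to compound 1 and a 3.6-fold lower number (0.56 log units; beyond the scatter) from compound 3 to compound 4, 1.8-fold (0.25 log units) apart, within the scatter of two such steps

For the compounds shown here, that agreement rests on only two pairs, and these differ in both the core and the state of the sulfur, so it does not show that the step stays the same whatever the core, nor why phenyl lowers the number. The compounds shown leave open how a plain sulfur and a sulfonyl sulfur compare on one and the same core, a comparison that would pull these two differences apart. They also leave open what an ethyl chain, a benzyl group or a phenyl ring carrying an amine would do on that sulfur.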